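A few compounds are considered here, and "the series" means these few. Any claim that something is new, unique, unknown or untested is made for them only; others in the source may bear on it.

Compound 1 `O=C(Oc1ccc(-c2cncn2C2CCN(C(=O)c3ccc(Cl)c(C(F)(F)F)c3)CC2)cc1)c1cccs1` gives in an assay on HEK293 cells for antagonist activity at P2X purinoceptor 7 (Homo sapiens), read by fluorescence, with a stated time of 2 h (a lower number here means a stronger inhibitor, a higher number a weaker inhibitor), only a limit, > 10000 nM. Going by the values given here, compound 2 `Nc1cccc(S(=O)(=O)Oc2ccc(-c3cncn3C3CCN(C(=O)c4ccc(Cl)c(C(F)(F)F)c4)CC3)cc2)c1` is the single compound with a number, 565 nM in this assay. Among the compounds with values here, the one measured step, an at least 17-fold lower number from compound 1 to compound 2 (1.24 log units; beyond the scatter), exchanges the whole group on the aromatic oxygen. Compound 3 `O=C(c1ccc(Cl)c(C(F)(F)F)c1)N1CCC(n2cncc2-c2ccc(OS(=O)(=O)c3cccc(Br)c3)cc2)CC1` differs from compound 2 in one place: bromo in place of amino on an aromatic carbon. The measured step does not touch this part of the molecule, so it offers no direct guide to the size or direction here. The expected step is a 1.1-fold higher number from compound 2 to compound 3 (0.03 log units; within the scatter), within the scatter. Compound 3 is therefore expected to give 600 nM, between 200 nM and 2000 nM.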

Compound 3, half-maximal inhibitory concentration: 896 nM
Beside the measured number, compound 3's estimate is 1.5-fold (0.17 log units) below it; measured number inside the range.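

In this assay, exchanging amino for bromo on this aromatic carbon gives a 1.6-fold higher number from compound 2 to compound 3 (0.20 log units; within the scatter), so the hydrogen-bond donor of the amino group is not needed to stay in this range. Both sulfonyl compounds stand apart from the (thiophen-2-yl)carbonyl compound, and the bromo compound shows this with an at least 11-fold lower number from compound 1 to compound 3 (1.04 log units; beyond the scatter) as its step. Compound 1 gives only a limit of the assay, so this step has no exact size: the limit of > 10000 nM in this assay, at which 1 of the 3 values shown sits. The compounds shown leave open how a carboxylic acid or a methoxy group would fare on this aromatic carbon. They also leave open whether the sulfonyl group itself, rather than its 3-substituted phenyl ring, accounts for the step.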